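This account rests on a few compounds, and the source may have more. Where it says the series, first, only, none or still open, it means among the compounds named here.

Measured compounds and their values in an assay on isolated protein for inhibition of NUAK family SNF1-like kinase 2 (Homo sapiens), read by ADP-Glo, with a stated time of 60 min, tested at 10 uM, in the presence of a further agent that is not named here; on this read-out lower numbers stand for less inhibition and higher numbers for more inhibition at the one concentration tested (going by the name of the read-out):

Compound 1 `CCC(=O)Nc1cccc(Oc2nc(Nc3ccc(N(C)C)cc3OC)ncc2Cl)c1`: 15%
Compound 2 `CCC(=O)Nc1cccc(Oc2nc(Nc3ccc(N4CCC(OC)CC4)cc3OC)ncc2Cl)c1`: "not active" (no number reported)
Compound 3 `CCC(=O)Nc1cccc(Oc2nc(Nc3ccc(N4CCC(OC)CC4)cc3)ncc2Cl)c1`: 53.4%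

All three share one core and differ only in the group attached to the aniline ring that carries the amine substituent. Compound 2 stands with no single number: it was reported as "not active" (no number reported) in this assay, so it can only be read as weaker than or about level with compound 1, which gives 15%. Compound 3, lacking the methoxy group, gives 53.4%.

Compound 4 `CCC(=O)Nc1cccc(Oc2nc(Nc3ccc(N4CCCC4)cc3OC)ncc2Cl)c1` keeps the methoxy group of compound 2 and changes the amine: pyrrolidin-1-yl in place of 4-methoxypiperidin-1-yl on an aromatic carbon. Within the data shown here, no measured pair reports this exact change, so the size of the step cannot be read off. The two analogs that carry the methoxy group, compound 1 and compound 2, both sit at the low end of the read-out, and compound 4 carries that same methoxy group, so a small step in either direction, likely within the scatter, is expected in this assay.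

The inhibition of compound 4 in this assay is estimated at about 15%, with a plausible span from 0% to 40%.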

Compound 4, a percentage reported as inhibition, at one concentration (the size of the read-out at that concentration, not a potency): "not active" (no number reported)
Compound 4 has no reported number here; the estimate stays without a comparison.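

In this assay neither compound 2 nor compound 4 has a reported number, so no step can be read between them. No measured finding bears on this result. The compounds shown leave open how far replacing 4-methoxypiperidin-1-yl with pyrrolidin-1-yl changes inhibition, with or without the methoxy group on the ring.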